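Clearance in rat liver microsomes: the pyran-to-fluoropyridine exchange

This account rests on a few compounds, and the source may have more. Where it says the series, first, only, none or still open, it means among the compounds named here.

Measured so far:
compound 1 `CC#Cc1cncc(-c2ccc3c(c2)[C@@]2(COC(N)=N2)c2cc(Cl)ncc2O3)c1` — 21 mL.min-1.g-1
compound 2 `CC1(C#Cc2cncc(-c3ccc4c(c3)[C@@]3(COC(N)=N3)c3cc(C5=CCOCC5)ncc3O4)c2)COC1` — 73 mL.min-1.g-1
compound 3 `CC#Cc1cncc(-c2ccc3c(c2)[C@@]2(COC(N)=N2)c2cc(C4=CCCOC4)ncc2O3)c1` — 45 mL.min-1.g-1

In an ADME assay on microsomes from liver (Rattus norvegicus) for metabolic stability, read by LC-MS, using NADPH, with a stated time of 30 min, tested at 1 uM (a lower number here means slower removal, a higher number faster removal of the compound), compound 3 gives the second highest of the three numbers; compound 2 lies within the scatter of it, while compound 1 sits beyond the scatter on the lower side. Among the compounds with values here, the one step at this position, a 2.1-fold higher number from compound 1 to compound 3 (0.33 log units; beyond the scatter), is modest.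

Compound 4 `CC#Cc1cncc(-c2ccc3c(c2)[C@@]2(COC(N)=N2)c2cc(-c4ccnc(F)c4)ncc2O3)c1` is not yet measured. It differs from compound 3 by a group of 7 heavy atoms (5 carbon, 1 nitrogen, 1 fluorine; one six-membered aromatic ring with 1 hetero atom) in place of a group of 6 heavy atoms (5 carbon, 1 oxygen; one six-membered non-aromatic ring with 1 hetero atom), on an aromatic carbon. Within the data shown here, no measured step covers this exchange; only the step from compound 1 to compound 3 touches the same position, and that step was small. A step in this assay of at most modest size is therefore expected for compound 4, with no clear direction beyond the scatter, a 1.1-fold lower number from compound 3 to compound 4 (0.05 log units; within the scatter). Compound 4 is estimated at 40 mL.min-1.g-1, within 18 mL.min-1.g-1 to 90 mL.min-1.g-1.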

Compound 4, intrinsic clearance in microsomes: 20 mL.min-1.g-1
Compound 4: middle estimate off by 2.0-fold (0.30 log units), on the high side; the measured number falls inside the stated range.
By their numbers in this assay, from the lowest: compounds 4 and 1 (each within the scatter of the next); then compounds 3 and 2 (each within the scatter of the next).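

At this aromatic carbon the outcome depends on which ring is attached, not merely on replacing chloro with a ring: in this series, exchanging the six-membered non-aromatic ring for 2-fluoropyridin-4-yl lowers the clearance in (this assay) beyond the scatter (a 2.3-fold lower number from compound 3 to compound 4 (0.35 log units; beyond the scatter)). Against chloro, 2-fluoropyridin-4-yl shows no separation (a 1.1-fold lower number from compound 1 to compound 4 (0.02 log units; within the scatter)). A larger group here therefore does not by itself go with a higher number: compound 3 fits that link, and compound 4 goes against it.

Open, from the compounds shown here alone, is how an amine or a carboxylic acid at this carbon would compare with 2-fluoropyridin-4-yl. No measurement at hand accounts for these steps.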